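The source may hold more compounds than are shown below. What is called first, only, known or untested is meant among the compounds shown, and "the series" means these compounds.

Measured so far in a functional assay (aorta) with Rattus norvegicus as the target; a lower number here means a stronger inhibitor, a higher number a weaker inhibitor:
Compound 1 `CCCCc1cn2ccccc2c1S(=O)(=O)c1ccc(OCCCN(CCC)CCC)cc1` gives 570 nM.
Compound 2 `CCCCc1cn2ccccc2c1S(=O)(=O)c1ccc(OCCCN(CCCC)CCCC)cc1` gives 284 nM.
Compound 3 `CCCN(CCC)CCCOc1ccc(S(=O)(=O)c2c(C(C)C)cn3ccccc23)cc1` gives 102 nM.

Compound 4 `CCCCN(CCCC)CCCOc1ccc(S(=O)(=O)c2c(C(C)C)cn3ccccc23)cc1` is not yet measured in this assay.

The series is built on a shared core; compounds 1 and 2 carry one form of it, compounds 3 and 4 another. The two cores differ by isopropyl in place of butyl on an aromatic carbon. That change alone gives a 5.6-fold lower number from compound 1 to compound 3 (0.75 log units; beyond the scatter), and compound 3 stands with the lowest number of the three, with compound 2 and compound 1 both beyond the scatter from it.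

The amine change is seen once in the measured set: compound 1 to compound 2 is dibutylamino in place of dipropylamino on a saturated chain carbon, three bonds along the chain from an oxygen on an aromatic ring, and gives a 2.0-fold lower number from compound 1 to compound 2 (0.30 log units; within the scatter). The step from compound 3 to compound 4 is the same change, (dibutylamino in place of dipropylamino on a saturated chain carbon, three bonds along the chain from an oxygen on an aromatic ring), made on the core of compound 3 instead; the place is the same in both cases.

One measured instance of the change is a thin basis, and that instance lies within the scatter. Compound 4 is expected to land close to compound 3, with a step of about a 1.7-fold lower number from compound 3 to compound 4 (0.23 log units; within the scatter), resting only on compound 1 to compound 2 showing a 2.0-fold lower number from compound 1 to compound 2 (0.30 log units; within the scatter) and on compound 3 giving 102 nM. Compound 4 is therefore estimated at 60 nM, with a likely range from 25 nM to 150 nM; whether the amine change reads the same on the core of compound 3 remains to be seen.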

Compound 4, half-maximal inhibitory concentration: 21.6 nM
Beside the measured number, compound 4's estimate is 2.8-fold (0.44 log units) above it; measured number below the stated range.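

In this assay, dibutylamino in place of dipropylamino gives a 4.7-fold lower number from compound 3 to compound 4 (0.67 log units; beyond the scatter), and this step does not differ measurably from the one seen on the other core: the same change on two cores in this assay, a 2.0-fold lower number (0.30 log units; within the scatter) from compound 1 to compound 2 and a 4.7-fold lower number (0.67 log units; beyond the scatter) from compound 3 to compound 4, 2.4-fold (0.37 log units) apart, within the scatter of two such steps

With dibutylamino on both cores, isopropyl in place of butyl on an aromatic carbon gives a 13-fold lower number from compound 2 to compound 4 (1.12 log units; beyond the scatter), which likewise agrees with its earlier counterpart: the same change on two cores in this assay, a 5.6-fold lower number (0.75 log units; beyond the scatter) from compound 1 to compound 3 and a 13-fold lower number (1.12 log units; beyond the scatter) from compound 2 to compound 4, 2.4-fold (0.37 log units) apart, within the scatter of two such steps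

Both changes therefore read as transferable between these two cores, and the result for compound 4 fits the two changes acting independently, but this rests on a single pair of steps for each change, the earlier amine step lies within the scatter, and neither a general rule for the series nor a cause follows from four compounds.

The compounds shown leave open whether dipentylamino or a ring amine such as piperidine would continue the step seen from dipropylamino to dibutylamino, and whether cyclopropyl or tert-butyl in place of isopropyl would read the same. They also leave open whether both changes would hold their size with a shorter or longer chain between the oxygen and the amine.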